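The compounds below may be only part of what the source reports. "The series", "measured", "known", "first", "only" and "open" are said of these compounds alone.

Of the compounds shown here, two have been measured so far. Compound 1 is `CC[C@@H]1CN(c2scnc2-c2nc3ccccc3[nH]2)CCN1C(=O)Cn1cnc2cccnc21`, and in an assay on blood for inhibition of C-X-C chemokine receptor type 3 (Homo sapiens), with a stated time of 30 min (a lower number here means a stronger inhibitor, a higher number a weaker inhibitor), compound 1 gives 851 nM. Compound 2 is `Cc1nc(C)n(CC(=O)N2CCN(c3sc(C(F)(F)F)nc3-c3cnc(OC4CCC4)nc3)C[C@H]2C)n1`, and in this assay compound 2 gives 306 nM. Within the data shown here, of the two numbers, that of compound 2 is the lower; compound 1, its only neighbour, gives a higher number, and the gap between them lies beyond the usual scatter of repeated measurements.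

Compound 3 is `COc1ccc(-c2nc(C(F)(F)F)sc2N2CCN(C(=O)Cn3nc(C)nc3C)[C@H](C)C2)cn1` and has not yet been measured. It differs from compound 2 in one place: 6-methoxypyridin-3-yl in place of 2-(cyclobutyloxy)pyrimidin-5-yl on an aromatic carbon. Among the measured compounds shown here, no pair of measured compounds shows this or any single change, so nothing measured says how large a step to expect from it; the expectation can rest only on the value of compound 2 in this assay, which is 306 nM. The change is expected to shift the number little, at most by a step of about the size of the scatter and, if anywhere, toward a weaker inhibitor: the step from compound 2 to compound 3 is estimated as a 1.6-fold higher number from compound 2 to compound 3 (0.21 log units; within the scatter). Compound 3 is thus expected to give about 500 nM in this assay, with a likely range from 200 nM to 1500 nM.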

Compound 3, half-maximal inhibitory concentration: 1580 nM
Beside the measured number, compound 3's estimate is 3.2-fold (0.50 log units) below it, outside the stated range (above it).
By their numbers in this assay, from the lowest: compound 2; then compounds 1 and 3 (each within the scatter of the next).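

Among these compounds, the aromatic carbon next to the ring nitrogen, two ring bonds from the ring atom that bears a trifluoromethyl group, proves sensitive to what it carries: in this assay putting 6-methoxypyridin-3-yl in place of 2-(cyclobutyloxy)pyrimidin-5-yl gives a 5.2-fold higher number from compound 2 to compound 3 (0.71 log units; beyond the scatter) and is the first single change that can be read at all. The exchange removes the four-membered ring of carbon only and replaces a six-membered aromatic ring with 2 hetero atoms by one with 1 hetero atom, so this one step cannot be assigned to either part of the change. Nothing measured bears on why the number rises.

The compounds shown leave open which part carries the step: a 2-methoxypyrimidin-5-yl group on this carbon would join the ring of compound 2 to the methoxy group of compound 3, and a 6-(cyclobutyloxy)pyridin-3-yl group would do the reverse. Also open, as far as these compounds go, is how a 2-aminopyrimidin-5-yl group, with an amine in place of the ether, would read in this assay on the same core.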